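Cytotoxicity of a Sulfonamide Variant with a Fused Ether Ring

A few compounds are considered here, and "the series" means these few. Any claim that something is new, unique, unknown or untested is made for them only; others in the source may bear on it.

compound 1 `CC(C)(C)OC(=O)Nc1ncc(C(Oc2ccc3cc(Br)ccc3c2)c2ccc(Cl)cc2)s1` — an ADME assay on HepG2 2.2.15 cells (Homo sapiens) for cytotoxicity; on this read-out lower numbers stand for higher toxicity in this test and higher numbers for lower toxicity in this test: > 50000 nM
compound 2 `CCCCC(CC)CNc1ncc(C(Oc2ccc3cc(Br)ccc3c2)c2ccc(Cl)cc2)s1` — "not toxic" (no number reported)
compound 3 `Cc1ccc(C)c(S(=O)(=O)Nc2ncc(C(Oc3ccc4cc(Br)ccc4c3)c3ccc(Cl)cc3)s2)c1` — > 50000 nM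

In this assay compound 3 stands only at a limit of the assay, not at a number. Compound 1 likewise reaches only a limit. Compound 2 is recorded without a number. The step that the two limits leave unreadable from compound 1 to compound 3 cannot be read, since both of its ends sit at the limit of > 50000 nM in this assay, at which 2 of the 3 values shown sit.

Compound 4 `O=S(=O)(Nc1ncc(C(Oc2ccc3cc(Br)ccc3c2)c2ccc(Cl)cc2)s1)c1ccc2c(c1)CCO2` differs from compound 3 by a group of 9 heavy atoms (8 carbon, 1 oxygen; one five-membered non-aromatic ring with 1 hetero atom, one six-membered aromatic ring of carbon only) in place of a group of 8 heavy atoms (8 carbon; one six-membered aromatic ring of carbon only), on a sulfonyl sulfur. Among the compounds with values here, no measured step touches the group on the sulfonyl sulfur, so the only guide is that every value shown sits at a limit or carries no number. Compound 4 is therefore expected to remain at the same limit, a step of a number no higher from compound 3 to compound 4 (the limit leaves the size open) meaning no change beyond the scatter. The estimate for compound 4 is 50000 nM, expected between 20000 nM and 120000 nM.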

Compound 4, half-maximal cytotoxic concentration: > 50000 nM
Compound 4: only a limit was reported (the forecaster's own chance of this, stated with the estimate: 80%); the middle value sits exactly at the limit.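

In this assay compound 4 reaches only a limit, as do compound 1 and compound 3, so no step among these compounds can be read: the limit of > 50000 nM in this assay, at which 3 of the 4 values shown sit.

The compounds shown leave open how far any of them lies from that limit and whether the group on the sulfonyl sulfur changes the read-out at all.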